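A triazole-linked hydroxypropyl chain replaces the hydroxybutyl group

A few compounds are considered here, and "the series" means these few. Any claim that something is new, unique, unknown or untested is made for them only; others in the source may bear on it.

Among the measured compounds shown here, compound 2 `CC(C)Cn1c(=O)n(C)c(=O)c2nc(CCCCO)c(Cc3cccc4ccccc34)nc21` is the only compound with a number in a functional assay on Raji cells (Homo sapiens) for inhibition, read by MTT assay, with a stated time of 96 h (a higher number here means that more compound is needed for the effect, a lower number that less compound is needed), where compound 2 gives 285 nM. Compound 1 `CC(C)Cn1c(=O)n(C)c(=O)c2nc(C(=O)N(C)CCCO)c(Cc3cccc4ccccc34)nc21` gives only a limit, > 10000 nM. For the measured compounds named here, the single measured step, an at least 35-fold lower number from compound 1 to compound 2 (1.54 log units; beyond the scatter), is the one that bears on the change to compound 3 `CC(C)Cn1c(=O)n(C)c(=O)c2nc(-c3[nH]nnc3CCCO)c(Cc3cccc4ccccc34)nc21`, namely (4-(3-hydroxypropyl)-1H-1,2,3-triazol-5-yl in place of 4-hydroxybutyl on an aromatic carbon). That step shows the number disappearing when the carbamoyl group stands in place of the chain. For compound 3 the expected step in this assay is a 5.3-fold higher number from compound 2 to compound 3 (0.72 log units; beyond the scatter), a smaller weakening. Compound 3 is therefore estimated at 1500 nM, between 400 nM and 8000 nM.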

Compound 3, half-maximal effective concentration: 6020 nM
Compound 3: the middle estimate sits 4.0-fold (0.60 log units) below what was measured, within the range that was stated.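

The change to 4-(3-hydroxypropyl)-1H-1,2,3-triazol-5-yl in place of 4-hydroxybutyl brings a 21-fold higher number from compound 2 to compound 3 (1.32 log units; beyond the scatter), so in this assay a second replacement of the chain at this position also loses most of the effect, here with a measurable number. Against the carbamoyl group, the triazole-bearing group gives an at least 1.6-fold lower number from compound 1 to compound 3 (0.22 log units; that floor lies within the scatter), so the two cannot be firmly ordered. Compound 1 stands only as a limit: the limit of > 10000 nM in this assay, at which 1 of the 3 values shown sits.

As far as these compounds go, whether the loss belongs to the triazole ring or to the hydroxypropyl chain on it stays open. So does whether an amine or a carboxylic acid in place of the terminal hydroxyl, or a longer chain, would keep the effect.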